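Removing an Aromatic Methyl in Two Related Pairs

The source may hold more compounds than are shown below. What is called first, only, known or untested is meant among the compounds shown, and "the series" means these compounds.

Of the compounds shown here, three have been measured in an ADME assay on HUVEC cells (Homo sapiens) for cytotoxicity, read by MTT assay, with a stated time of 24 h (a lower number here means a stronger inhibitor, a higher number a weaker inhibitor), and a fourth awaits its measurement. Compound 1 `COc1cc(C2Oc3cc(-c4oc5cc(O)cc(O)c5c(=O)c4OC)ccc3OC2CO)ccc1O` gives 22500 nM in this assay. Compound 2 `COc1cc(O)c2c(=O)c(OC)c(-c3ccc4c(c3)OC(c3ccc(O)c(OC)c3)C(CO)O4)oc2c1` gives 43100 nM in this assay. Compound 3 `COCC1Oc2ccc(-c3oc4cc(OC)cc(O)c4c(=O)c3O)cc2OC1c1ccc(O)c(OC)c1` gives 14500 nM in this assay, the lowest of the three numbers; its gap to compound 1 lies within the scatter, while its gap to compound 2 lies beyond it.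

Compound 2 and compound 1 differ in one place: hydrogen in place of methyl on an oxygen on an aromatic ring. This change made the step of a 1.9-fold lower number from compound 2 to compound 1 (0.28 log units; within the scatter).

The cores of compound 3 and compound 2 are built from the same atoms joined differently; the difference between the two cores is not broken down here.

Compound 4 `COCC1Oc2ccc(-c3oc4cc(O)cc(O)c4c(=O)c3O)cc2OC1c1ccc(O)c(OC)c1` has not yet been measured. Within the data shown here, it differs from compound 3 by hydrogen in place of methyl on an oxygen on an aromatic ring, which is the same change as the one from compound 2 to compound 1, at a place described in the same words. The expectation for compound 4 therefore rests on the step of a 1.9-fold lower number from compound 2 to compound 1 (0.28 log units; within the scatter), which lay within the scatter. The expected step is accordingly small, a 1.4-fold lower number from compound 3 to compound 4 (0.14 log units; within the scatter), and should not be read as a real change in this assay. Compound 4 is estimated to give 10500 nM in this assay. Compound 4 is expected to fall between 5000 nM and 24000 nM in this assay.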

Compound 4, half-maximal inhibitory concentration: 28300 nM
Compound 4: the middle estimate sits 2.7-fold (0.43 log units) below what was measured; measured number outside the range, above it.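

In this assay the change from methoxy to hydroxy gave a 2.0-fold higher number from compound 3 to compound 4 (0.29 log units; within the scatter) and thus ran the opposite way to the earlier step, although neither step on its own lies beyond the scatter. Set side by side, the two steps show that this change did not carry from one core to the other in this series as a step of fixed direction and size: the same change on two cores in this assay, a 1.9-fold lower number (0.28 log units; within the scatter) from compound 2 to compound 1 and a 2.0-fold higher number (0.29 log units; within the scatter) from compound 3 to compound 4, 3.7-fold (0.57 log units) apart, beyond the scatter of two such steps

This does not show why the two cores part, and neither step alone can be read as a real change on its own core, so two pairs give no rule for predicting the change on any further core.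

The compounds shown leave open whether the same split between the two cores would appear with other groups on this oxygen, such as an ethyl group, a longer chain or a chain ending in an amine. They also leave open whether a further core carrying the same change would follow the pair of compound 2 and compound 1, the pair of compound 3 and compound 4, or neither of them.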